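Swapping a methyl for an ethoxy on the catechol chalcone

The source may hold more compounds than are shown below. What is called first, only, known or untested is meant among the compounds shown, and "the series" means these compounds.

Compound 3 `Cc1ccc(O)c(C(=O)/C=C/c2ccc(O)c(O)c2)c1` is one of three related compounds tested in an assay on RBL-1 cells for inhibition of Polyunsaturated fatty acid 5-lipoxygenase (Rattus norvegicus) (a lower number here means a stronger inhibitor, a higher number a weaker inhibitor), where compound 3 gives 39 nM. Its two neighbours each differ from it in a single position. Compound 1 `Cc1cccc(C(=O)/C=C/c2ccc(O)c(O)c2)c1` lacks the hydroxy group on the ring that carries the carbonyl; in this assay compound 1 gives 27 nM, and the step is a 1.4-fold higher number from compound 1 to compound 3 (0.16 log units; within the scatter). Compound 2 `O=C(/C=C/c1ccc(O)c(O)c1)c1cc(O)ccc1O` carries a hydroxy where compound 3 has a methyl; in this assay compound 2 gives 64 nM, and the step is a 1.6-fold lower number from compound 2 to compound 3 (0.22 log units; within the scatter). Both steps stay within the scatter, so the three compounds cannot be told apart on these numbers.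

Compound 4 `CCOc1ccc(O)c(C(=O)/C=C/c2ccc(O)c(O)c2)c1` continues this series with the change (ethoxy in place of methyl on an aromatic carbon). The step from compound 2 to compound 3, which exchanged groups at the same position, bears most directly on it, and the step from compound 1 to compound 3 shows that a second change on this ring also moved little. No step beyond the scatter is therefore expected in this assay. The expected step is a 1.0-fold higher number from compound 3 to compound 4 (0.01 log units; within the scatter). Compound 4 is estimated to give about 40 nM, within a range of 15 nM to 110 nM.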

Compound 4, half-maximal inhibitory concentration: 5.3 nM
For compound 4 the middle estimate is 7.5-fold (0.88 log units) above the measured one; the whole stated range lies above it.
By their numbers in this assay, from the lowest: compound 4; then compounds 1, 3 and 2 (each within the scatter of the next, the first and the last beyond it).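

In this assay, among these compounds, the place para to a hydroxy group turns out to be sensitive: ethoxy in place of methyl gives a 7.4-fold lower number from compound 3 to compound 4 (0.87 log units; beyond the scatter) and ethyl in place of hydrogen on the oxygen gives a 12-fold lower number from compound 2 to compound 4 (1.08 log units; beyond the scatter) even though the earlier steps stayed within the scatter. Methyl and hydroxy could not be told apart here, yet adding an ethyl to that hydroxy oxygen moves the number well beyond the scatter. Nothing shown here gives a reason for this drop.

The compounds shown carry only methyl, hydroxy or ethoxy at this place, so a methoxy, a propoxy or an amine would be needed to tell whether the drop follows the oxygen, the ethyl or the whole group. Also open, going by these compounds, is whether ethoxy lowers the number as far without the hydroxy group on the same ring.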